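Two Dimeric Acylphloroglucinols Compared by Acyl Chain Length

The source may report more compounds than this note shows. Statements on the series, on what has been measured and on what is new or still open speak of the compounds shown alone.

Compound 1, with structure `CCC(=O)C1=C(O)C(C)(C)C(O)=C(Cc2c(O)c3c(c(C(C)=O)c2O)OC(C)(C)C=C3)C1=O`, carries a propanoyl group and an acetyl group on its shared core. A close relative, compound 2, has structure `CCC(=O)C1=C(O)C(C)(C)C(O)=C(Cc2c(O)c3c(c(C(=O)CC)c2O)OC(C)(C)C=C3)C1=O` and carries a propanoyl group in place of each of these. In a functional assay on cells (Cancer cell lines, Homo sapiens) for cytotoxicity, with a stated time of 72 h (on this read-out lower numbers stand for an effect already at smaller amounts and higher numbers for an effect only at larger amounts of compound), compound 2 gives 3.4 ug/mL. In this assay, as far as these compounds go, compound 1 gives "not determined" (no result reported), so its place on this scale is unknown, and nothing can be said about how the two differ in effect.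

Compound 3, with structure `CC(=O)C1=C(O)C(C)(C)C(O)=C(Cc2c(O)c3c(c(C(C)=O)c2O)OC(C)(C)C=C3)C1=O`, is the third member of the set. It differs from compound 1 by one small change: hydrogen in place of methyl on a saturated chain carbon bound to a carbonyl carbon. Both acyl groups of compound 3 are therefore acetyl.

Because compound 1 lacks a measurement, the size of this step cannot be read from the data. A change of a single carbon on a short chain is expected to shift the result in this assay by no more than the usual scatter, in either direction. Compound 3 is therefore expected to give about 4 ug/mL, within a range from 1.5 ug/mL to 12 ug/mL.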

Compound 3, concentration for half-maximal effect: 5.1 ug/mL
Estimate against measurement, compound 3: 1.3-fold (0.11 log units) below; low and high end bracket the measured number.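

Going by these compounds alone, compound 1 has no single number in this assay, so no step from it to compound 3 can be read. The compounds shown leave open how far replacing one propanoyl group with acetyl, on its own, moves cytotoxicity. No data here bear on why compound 3 gives its result.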